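Swapping the Aryl Group on the Hydrazide Carbonyl

A few compounds are considered here, and "the series" means these few. Any claim that something is new, unique, unknown or untested is made for them only; others in the source may bear on it.

Measured compounds:
compound 1, `CC(/C=N/N(C)c1ccc([N+](=O)[O-])cc1)=N\NC(=O)c1ccccc1O`, 3120 nM
compound 2, `CC(/C=N/N(C)c1ccc([N+](=O)[O-])cc1)=N\NC(=O)c1cc([N+](=O)[O-])cc([N+](=O)[O-])c1`, 1110 nM
compound 3, `CC(/C=N/Nc1ccc([N+](=O)[O-])cc1)=N\NC(=O)c1ccccc1N`, 4900 nM

All three were tested in a functional assay on cells (Splenocyte, Mus musculus, strain BALB/c) for inhibition, read by scintillation counting and thymidine incorporation, with a stated time of 72 h; a lower number here means a stronger inhibitor, a higher number a weaker inhibitor. Compound 3 gives the highest of the three numbers, 4900 nM. Its nearest neighbour is compound 1 at 3120 nM, a gap that stays within the scatter, so the two cannot be placed in order. Compound 2 at 1110 nM stands further off, with a gap beyond the scatter, so compound 2 is the stronger inhibitor of that pair.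

The next compound, compound 4, `COc1cc(C(=O)N/N=C(C)/C=N/Nc2ccc([N+](=O)[O-])cc2)ccc1O`, has not yet been measured in this assay. It differs from compound 3 in one place: 4-hydroxy-3-methoxyphenyl in place of 2-aminophenyl on a carbonyl carbon

Among the measured compounds shown here, no measured pair in this set shares exactly this change, so the expected size of the step rests on little. The three measured aryl groups on the carbonyl carbon span a modest range, so for compound 4 the step from compound 3 is expected to be small, a 1.3-fold lower number from compound 3 to compound 4 (0.11 log units; within the scatter), most likely within the scatter and, if anything, toward a lower number. For compound 4 the estimate in this assay is 3800 nM, with a range from 1400 nM to 11000 nM.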

Compound 4, half-maximal inhibitory concentration: 5100 nM
Compound 4: the middle estimate sits 1.3-fold (0.13 log units) below what was measured, within the range that was stated.
By their numbers in this assay, from the lowest: compound 2; then compounds 1, 3 and 4 (each within the scatter of the next).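

In this assay, putting 4-hydroxy-3-methoxyphenyl in place of 2-aminophenyl on the carbonyl carbon gives a 1.0-fold higher number from compound 3 to compound 4 (0.02 log units; within the scatter), so compound 3 and compound 4 cannot be placed in order. Among the compounds shown here, this is the first step in the set that changes only one place, and it shows that the number at this position stays within the scatter when a group of 7 heavy atoms, with nitrogen as its only non-carbon atom, gives way to one of 9 heavy atoms carrying two oxygens. No measurement is available that would explain why the two groups give such similar numbers.

Compound 1 and compound 2 differ from compound 3 and compound 4 in more than one place, so the compounds shown do not reveal how much the aryl group alone can move the number. They also leave open whether this position would keep its number with a group that has no aromatic ring, such as a cyclohexyl ring or a longer alkyl chain, or with a phenyl ring carrying a carboxylic acid.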